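The compounds below may be only part of what the source reports. "The series", "measured", "known", "first", "only" and "open" are said of these compounds alone.

In a functional assay on Raji cells (Homo sapiens) for inhibition, read by MTT assay, with a stated time of 96 h (on this read-out higher numbers stand for an effect only at larger amounts of compound and lower numbers for an effect already at smaller amounts), compound 1 (`CC(C)Cn1c(=O)n(C)c(=O)c2[nH]c(=O)c(Cc3cccc4ccccc34)nc21`) gives > 10000 nM as its reading, which is a limit and not a number. Compound 2 (`CC(C)Cn1c(=O)n(C)c(=O)c2c1nc(Cc1cccc3ccccc13)c(=O)n2CCCCO`) gives 150 nM in this assay as a true number. Among the compounds with values here, the only measured step between compounds that differ in one place is large (an at least 66-fold lower number from compound 1 to compound 2 (1.82 log units; beyond the scatter)). Compound 3 (`CC(C)Cn1c(=O)n(C)c(=O)c2nc(SCCO)c(Cc3cccc4ccccc34)nc21`) gives 2850 nM and so holds the higher of the two true numbers, the other being that of compound 2.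

Compound 4 (`CC(C)Cn1c(=O)n(C)c(=O)c2nc([S+]([O-])CCCO)c(Cc3cccc4ccccc34)nc21`) differs from compound 3 in one place: on an aromatic carbon the (2-hydroxyethyl)sulfanyl group leaves and a group with no common name enters (a group of 6 heavy atoms (3 carbon, 2 oxygen, 1 sulfur; no ring) in place of a group of 4 heavy atoms (2 carbon, 1 oxygen, 1 sulfur; no ring), on an aromatic carbon). The large measured step lies on an aromatic nitrogen, not on this carbon, so it says little about this change. The expectation therefore starts from compound 3 at 2850 nM and foresees no step beyond the scatter in this assay. The expected change is small (a 1.1-fold lower number from compound 3 to compound 4 (0.06 log units; within the scatter)). For compound 4 the estimated value is 2500 nM with an expected range from 700 nM to 9000 nM as its bounds.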

Compound 4, half-maximal effective concentration: 1990 nM
For compound 4 the middle estimate is 1.3-fold (0.10 log units) above the measured one; low and high end bracket the measured number.
By their numbers in this assay, from the lowest: compound 2; then compounds 4 and 3 (each within the scatter of the next). At a limit, above all of these: compound 1.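

In this assay, within the data shown here, the first step on this aromatic carbon next to the ring nitrogen is a 1.4-fold lower number from compound 3 to compound 4 (0.16 log units; within the scatter). The earlier step concerned an aromatic nitrogen, whereas this one shows that replacing (2-hydroxyethyl)sulfanyl with the larger group of 6 heavy atoms, which has the same hydrogen-bond donor and acceptor counts, leaves the reading within the usual scatter, so compounds 3 and 4 cannot be told apart here. The data shown give no measured property that could explain this result.

Going by these compounds, a single pair cannot show how much change this carbon accepts, so it remains open whether an amine or a carboxylic acid here would move the reading beyond the scatter. On these data alone, it also remains open whether a longer chain ending in a hydroxyl group would do so.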